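Chloro-to-fluoro exchange on the aryl group, two cores

The source may hold more compounds than are shown below. What is called first, only, known or untested is meant among the compounds shown, and "the series" means these compounds.

Measured so far:
compound 1 `C[C@H]1CC[C@@H]2[C@@H](OC(=O)[C@]23CC(c2ccccc2F)=NO3)[C@]2(C)C(=O)C=C[C@@]12O` gives 1.58 in a physicochemical assay for lipophilicity; on this read-out lower numbers stand for lower lipophilicity and higher numbers for higher lipophilicity
compound 2 `C[C@H]1CC[C@@H]2[C@@H](OC(=O)[C@]23CC(c2ccccc2Cl)=NO3)[C@]2(C)C(=O)C=C[C@@]12O` gives 2.09 in this assay
compound 3 `C[C@H]1CC[C@@H]2[C@@H](OC(=O)[C@]23CC(c2ccc(Cl)cc2)N(c2ccccc2)O3)[C@]2(C)C(=O)C=C[C@@]12O` gives 3.87 in this assay

Compounds 1 and 2 share one core; compound 3 sits on a second core, and the difference between the two cores is not broken down here. Compound 3 has the highest value of the three; its nearest neighbour is compound 2, and compound 1 lies furthest from it.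

Within the first core, one change is measured: fluoro in place of chloro on an aromatic carbon. It gives a number 0.51 log units lower from compound 2 to compound 1 (beyond the scatter).

Compound 4 `C[C@H]1CC[C@@H]2[C@@H](OC(=O)[C@]23CC(c2ccc(F)cc2)N(c2ccccc2)O3)[C@]2(C)C(=O)C=C[C@@]12O` has not yet been measured. It differs from compound 3 by fluoro in place of chloro on an aromatic carbon. Going by the values given here, this is the same kind of change as the one from compound 2 to compound 1, but not the same: in the first pair the halogen sits ortho to a large group, in the second pair it sits para to a large group. The change occurs twice in all among the compounds shown, once measured and once not.

For compound 4 the step in this assay is expected to be a number 0.50 log units lower from compound 3 to compound 4 (beyond the scatter) because a number 0.51 log units lower from compound 2 to compound 1 (beyond the scatter) is the measured step for the same kind of exchange of chloro for fluoro. The expectation rests on that single pair only, so the range is kept wide. Compound 4 is estimated at 3.37, within 3 to 3.75.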

Compound 4, partition coefficient: 3.35
Beside the measured number, compound 4's estimate is 0.02 log units above it; low and high end bracket the measured number.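

In this assay, the 4-chlorophenyl to 4-fluorophenyl exchange gives a number 0.52 log units lower from compound 3 to compound 4 (beyond the scatter), close in size to a number 0.51 log units lower from compound 2 to compound 1 (beyond the scatter), so in these two pairs the step carries over from one core to the other, even though the halogen sits para to a large group in the new pair and at another place on the ring in the earlier one. This agreement rests on two pairs on two cores and does not establish a rule for the series; the core and the place of the halogen differ together between the pairs, so the two pairs cannot separate their contributions. Nothing available here bears on the reason for the size of either step.

The compounds shown leave open whether the step stays the same when the halogen occupies the same place on both cores, and whether it would hold on a further core. On these data alone, they also include no aryl group carrying a nitrile, a methoxy group, an amine or a carboxylic acid in place of the halogen, so how such exchanges would compare across the two cores remains unknown.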